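A few compounds are considered here, and "the series" means these few. Any claim that something is new, unique, unknown or untested is made for them only; others in the source may bear on it.

Within the data shown here, in a functional assay on HeLa cells (Homo sapiens) for cytotoxicity, read by sulforhodamine B assay (on this read-out higher numbers stand for weaker inhibition and lower numbers for stronger inhibition), compound 1 (`CC(C)C(NS(=O)(=O)c1ccc(Cl)cc1)C1=CC(=O)c2c(O)ccc(O)c2C1=O`) gives 8650 nM and sits at the upper end of the three numbers so far, level with compound 2 (`CC(C)C(NS(=O)(=O)c1ccccc1Br)C1=CC(=O)c2c(O)ccc(O)c2C1=O`) at 8310 nM and clear of compound 3 (`CC(=O)c1ccc(S(=O)(=O)NC(C2=CC(=O)c3c(O)ccc(O)c3C2=O)C(C)C)cc1`) at 3820 nM in the same read-out. The three measured steps are a 1.0-fold lower number from compound 1 to compound 2 (0.02 log units; within the scatter) for the 2-bromophenyl swap, then a 2.3-fold lower number from compound 1 to compound 3 (0.35 log units; beyond the scatter) and a 2.2-fold lower number from compound 2 to compound 3 (0.34 log units; beyond the scatter) on reaching the acetyl-bearing group. All of them change only the group on the sulfonyl sulfur.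

Compound 4 (`CC(NS(=O)(=O)c1ccc(Cl)cc1)C1=CC(=O)c2c(O)ccc(O)c2C1=O`) keeps the 4-chlorophenyl group of compound 1 and changes the other side of the sulfonamide nitrogen (methyl in place of isopropyl on a saturated chain carbon bound to a double-bonded ring carbon and a sulfonamide nitrogen): methyl in place of isopropyl on a saturated chain carbon bound to a double-bonded ring carbon and a sulfonamide nitrogen. Among the measured compounds shown here, no measured compound varies this carbon, so the series gives no direct size or direction for the change. The sulfonyl-side steps serve only as a rough guide to how far the numbers move, with a 2.3-fold lower number from compound 1 to compound 3 (0.35 log units; beyond the scatter) as the largest seen. The expected result is a 1.2-fold lower number from compound 1 to compound 4 (0.09 log units; within the scatter) and thus no shift beyond the scatter, with a wide margin on either side. Compound 4 is estimated at 7000 nM (range 3000 nM to 16000 nM).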

Compound 4, half-maximal inhibitory concentration: 810 nM
Beside the measured number, compound 4's estimate is 8.6-fold (0.94 log units) above it; the measured number lies below the stated range.
By their numbers in this assay, from the lowest: compound 4; then compound 3; then compounds 2 and 1 (each within the scatter of the next).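

In this assay, the saturated chain carbon bound to a double-bonded ring carbon and a sulfonamide nitrogen emerges as the most sensitive place varied so far: methyl in place of isopropyl gives an 11-fold lower number from compound 1 to compound 4 (1.03 log units; beyond the scatter) and so exceeds the largest step on the sulfonyl side, which is a 2.3-fold lower number from compound 1 to compound 3 (0.35 log units; beyond the scatter) in this series. The direction is also new, as the smaller group, with 1 heavy atom against 3, goes with the lower number and so with stronger inhibition on this read-out, although a single pair sets no trend with chain size. Nothing available accounts for the size of this step.

The compounds shown leave open how the number changes with an ethyl group, a longer chain or an amine-bearing chain on this carbon, so the shape of the response beyond methyl and isopropyl remains unknown. Also open, on these data alone, is whether methyl gives a step of similar size when paired with the 2-bromophenyl group of compound 2 or the 4-acetylphenyl group of compound 3.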